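The compounds below may be only part of what the source reports. "The series", "measured", "known", "first", "only" and "open" are said of these compounds alone.

For the measured compounds named here, in an assay on HeLa cells for inhibition of Indoleamine 2,3-dioxygenase 1 (Homo sapiens) (on this read-out lower numbers stand for stronger inhibition and higher numbers for weaker inhibition), compound 1 `O=C(Nc1ccc(F)cc1)C1(c2ccc3c(n2)CCN3c2ccccn2)CCC1` gives 10.9 nM, the second highest of the three numbers measured so far: compound 3 `O=C(Nc1ccc(Cl)cc1)C1(c2ccc3c(n2)CCN3c2ccccn2)CCC1` gives 2.3 nM, while compound 2 `CC(C)C(=O)N1CCc2cc(CNC(=O)c3ccco3)ccc21` gives 92 nM. Going by the values given here, the only measured step between compounds that differ in one place is a 4.7-fold lower number from compound 1 to compound 3 (0.68 log units; beyond the scatter), and it concerns a halogen on an aromatic carbon, not the part of the core altered here. Compound 4 `O=C(Nc1ccc(F)cc1)C1(c2ccc3c(n2)CCN3c2ccnc(C(F)(F)F)n2)CCC1` differs from compound 1 as follows: 2-(trifluoromethyl)pyrimidin-4-yl in place of pyridin-2-yl on a nitrogen on an aromatic ring in a ring. Among the compounds with values here, no measured step touches this position, so that halogen step gives no direct guide to size or direction, and a step of at most modest size is expected, a 1.1-fold higher number from compound 1 to compound 4 (0.04 log units; within the scatter). Compound 4 is therefore estimated to give about 12 nM, within a range from 4 nM to 40 nM.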

Compound 4, half-maximal inhibitory concentration: 127 nM
For compound 4 the middle estimate is 11-fold (1.02 log units) below the measured one; measured number outside the range, above it.
By their numbers in this assay, from the lowest: compound 3; then compound 1; then compounds 2 and 4 (each within the scatter of the next).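

In this assay, replacing pyridin-2-yl with 2-(trifluoromethyl)pyrimidin-4-yl on this nitrogen gives a 12-fold higher number from compound 1 to compound 4 (1.07 log units; beyond the scatter) and so shows that inhibition responds strongly to the group at this position. The change adds a second ring nitrogen and a trifluoromethyl group together, and the two compounds cannot separate their contributions. Nothing available here accounts for the weaker inhibition.

On these data alone, it remains open whether plain pyrimidin-4-yl without the trifluoromethyl group would restore the number of compound 1. As far as these compounds go, how a pyridin-2-yl ring carrying a methyl group or an amine would behave also remains open.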